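Pyridin-2-yl in Place of a Dimethoxyphenyl Ketone Arm

The source may hold more compounds than are shown below. What is called first, only, known or untested is meant among the compounds shown, and "the series" means these compounds.

Three compounds with a shared core differ only in the ring on a carbonyl carbon. In a functional assay on MCF7 cells (Homo sapiens) for antiproliferative activity, read by XTT assay, with a stated time of 72 h (a higher number here means a weaker inhibitor, a lower number a stronger inhibitor), compound 1 `COc1ccc(-c2cc3ccccc3nc2/C=C/C(=O)c2ccc(F)cc2)cc1` gives 5450 nM, compound 2 `COc1ccc(-c2cc3ccccc3nc2/C=C/C(=O)c2ccc(OC)cc2OC)cc1` gives 6260 nM, and compound 3 `COc1ccc(-c2cc3ccccc3nc2/C=C/C(=O)c2cccs2)cc1` gives 1030 nM. Compound 2 has the highest number of the three: the step of a 1.1-fold higher number from compound 1 to compound 2 (0.06 log units; within the scatter) is within the scatter, whereas the step of a 6.1-fold lower number from compound 2 to compound 3 (0.78 log units; beyond the scatter) is beyond it. Compound 4 `COc1ccc(-c2cc3ccccc3nc2/C=C/C(=O)c2ccccn2)cc1` differs from compound 2 by pyridin-2-yl in place of 2,4-dimethoxyphenyl on a carbonyl carbon. The steps toward thiophen-2-yl, a 6.1-fold lower number from compound 2 to compound 3 (0.78 log units; beyond the scatter) and a 5.3-fold lower number from compound 1 to compound 3 (0.72 log units; beyond the scatter), are the ones that bear on swapping in another ring with a hetero atom, so a lower number is expected, though by a smaller margin; the expected step is a 2.5-fold lower number from compound 2 to compound 4 (0.40 log units; beyond the scatter). Compound 4 is therefore estimated at 2500 nM, within a range from 800 nM to 8000 nM.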

Compound 4, half-maximal inhibitory concentration: 810 nM
For compound 4 the middle estimate is 3.1-fold (0.49 log units) above the measured one; low and high end bracket the measured number.
By their numbers in this assay, from the lowest: compounds 4 and 3 (each within the scatter of the next); then compounds 1 and 2 (each within the scatter of the next).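

In this assay a second ring with a hetero atom also gives a lower number, with a 7.7-fold lower number from compound 2 to compound 4 (0.89 log units; beyond the scatter) and a 6.7-fold lower number from compound 1 to compound 4 (0.83 log units; beyond the scatter) pointing the same way, so thiophen-2-yl is not alone in this on the carbonyl carbon. With a 1.3-fold lower number from compound 3 to compound 4 (0.10 log units; within the scatter) pyridin-2-yl and thiophen-2-yl cannot be told apart here. Nothing measured here explains these steps. Still open, from the compounds shown here alone, is whether an amine or a carboxylic acid on the carbonyl carbon, in place of the ring, would keep the lower number.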